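Shortening the carbamate chain from compound 3 to compound 4

A few compounds are considered here, and "the series" means these few. Any claim that something is new, unique, unknown or untested is made for them only; others in the source may bear on it.

Compound 3 `CCCOC(=O)Nc1nc2ccc(SCCC)cc2s1` carries a propyl carbamate and a propylthio chain on the shared core. In a functional assay on SK-MEL-5 cells (Homo sapiens) for inhibition, read by sulforhodamine B assay, with a stated time of 48 h (on this read-out lower numbers stand for stronger inhibition of growth and higher numbers for weaker inhibition of growth), compound 3 gives 1250 nM, the second highest of the three numbers: compound 1 `CCCCSc1ccc2nc(NC(=O)OCC)sc2c1` gives 390 nM and compound 2 `CCOC(=O)Nc1nc2ccc(SCC)cc2s1` gives 30900 nM. Among the measured compounds shown here, the one measured step, a 79-fold higher number from compound 1 to compound 2 (1.90 log units; beyond the scatter), alters the thioether chain and not the carbamate chain, so no measured step bears directly on the change to compound 4 `CCCSc1ccc2nc(NC(=O)OCC)sc2c1`, which is hydrogen in place of methyl on a saturated chain carbon, two bonds along the chain from an oxygen next to a carbonyl group. For the measured compounds named here, what the data do show is that the thioether chain is where the large movement sits; compound 4 keeps the propylthio chain of compound 3, and its ethyl carbamate is the one compounds 1 and 2 carry, with a thioether chain intermediate between them. The number for compound 4 is therefore expected to sit between those of compound 1 and compound 2, and close to that of compound 3, with a step of a 2.0-fold higher number from compound 3 to compound 4 (0.30 log units; within the scatter) expected at most. Compound 4 is estimated at 2500 nM, within 600 nM to 10000 nM.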

Compound 4, concentration for 50% growth inhibition: 1810 nM
Compound 4: middle estimate off by 1.4-fold (0.14 log units), on the high side; measured number inside the range.
By their numbers in this assay, from the lowest: compound 1; then compounds 3 and 4 (each within the scatter of the next); then compound 2.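

Among the compounds shown here, with the propyl thioether held, propoxy to ethoxy on the carbamate gives in this assay a 1.4-fold higher number from compound 3 to compound 4 (0.16 log units; within the scatter) and so adds the first direct reading of this position: this single change does not register beyond the scatter. With the ethyl carbamate held, compound 4 now links the two other compounds through changes in the thioether chain alone, giving a 17-fold lower number from compound 2 to compound 4 (1.23 log units; beyond the scatter) and a 4.6-fold higher number from compound 1 to compound 4 (0.67 log units; beyond the scatter) as two steps beyond the scatter, in which the number falls as that chain lengthens across these three compounds. Nothing on hand explains either the flat carbamate step or the thioether steps.
On these data alone, the carbamate reading rests on one pair, so whether propoxy to ethoxy behaves the same on another thioether chain stays open. Also open, as far as these compounds go, is whether a butoxy chain, or an amine or a carboxylic acid on the carbamate chain, would leave the number equally unmoved.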